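The source may report more compounds than this note shows. Statements on the series, on what has been measured and on what is new or still open speak of the compounds shown alone.

Series notes. The shared core is that of compound 1, `N#CNC(=N)Nc1cccnc1`; in a functional assay on the whole organism (blood, strain Wistar-Okamoto) with Rattus norvegicus as the target, with a stated time of 5 days (a higher number here means that more compound is needed for the effect, a lower number that less compound is needed), compound 1 gives 50 mg/kg. Compound 2, `CCCCC(CC)C/N=C(\NC#N)Nc1cccnc1`, is known only as a limit of this assay: in this assay compound 2 returns > 50 mg/kg and no number (the limit of > 50 mg/kg in this assay, at which 1 of the 3 values shown sits). Compound 3, `CCC(C)/N=C(\NC#N)Nc1cccnc1`, holds the lower of the two numbers: in this assay compound 3 gives 20 mg/kg, and the gap to compound 1 is beyond the usual scatter. Among the measured compounds shown here, no pair of measured compounds differs in a single place, so no measured step can be quoted.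

Compound 4, `C=C(C)C/N=C(\NC#N)Nc1cccnc1`, remains to be measured. Against compound 3 the change is 2-methylprop-2-en-1-yl in place of sec-butyl on a double-bonded nitrogen. In this assay a small step is expected, none beyond the scatter, in either direction, because compound 3 gives 20 mg/kg with a chain of the same count. For compound 4 the estimate in this assay is 20 mg/kg, within 10 mg/kg to 50 mg/kg. The expected step of no change at the digits printed from compound 3 to compound 4 (within the scatter) therefore stays inside the scatter.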

Compound 4, minimum effective dose: 20 mg/kg
Compound 4: the middle estimate sits on the measured number at the digits printed; the range from low to high includes it.
By their numbers in this assay, from the lowest: compounds 3 and 4 (each within the scatter of the next); then compound 1.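

Among the compounds shown here, the reading no change at the digits printed from compound 3 to compound 4 (within the scatter) is the first single-place step in this assay and gives a direct comparison on a double-bonded nitrogen. At this place, 2-methylprop-2-en-1-yl in place of sec-butyl brings in one double bond outside aromatic rings at the same count of carbon, and the read-out does not separate the two groups. No measurement at hand gives a cause for this result.

Compound 2 remains a limit and not a number: the limit of > 50 mg/kg in this assay, at which 1 of the 4 values shown sits. Still open, on these data alone, is what a straight butyl chain, a cyclohexyl ring, a primary amine or a carboxylic acid would give on this nitrogen, so the reach of this equivalence beyond these two groups cannot be read.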